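This account rests on a few compounds, and the source may have more. Where it says the series, first, only, none or still open, it means among the compounds named here.

Going by the values given here, in a functional assay on HCT-116 cells (Homo sapiens) for cytotoxicity, read by MTT assay, with a stated time of 48 h, in the presence of a further agent that is not named here (on this read-out higher numbers stand for an effect only at larger amounts of compound and lower numbers for an effect already at smaller amounts), compound 1 (`COc1ccc(-c2cc(NNC(=O)Nc3cc(Br)nc(Br)c3)nc3c2cnn3C)cc1`) gives 45200 nM and compound 2 (`COc1ccc(-c2cc(NNC(=O)Nc3cc(Cl)nc(OC)c3)nc3c2cnn3C)cc1`) gives 54200 nM, so compound 2 stands level with the only other measured compound, within the scatter. Compound 3 (`CCCOc1cc(NC(=O)NNc2cc(-c3ccc(OC)cc3)c3cnn(C)c3n2)cc(Cl)n1`) differs from compound 2 by ethyl in place of hydrogen on a saturated chain carbon bound to an oxygen on an aromatic ring, which turns methoxy to propoxy. Among the compounds with values here, the one measured step, a 1.2-fold higher number from compound 1 to compound 2 (0.08 log units; within the scatter), altered the same group and stayed within the scatter, but no measured step lengthens this chain. No step beyond the scatter is therefore expected in this assay. The expected step, a 1.1-fold higher number from compound 2 to compound 3 (0.04 log units; within the scatter), is small. For compound 3 the estimated value is 60000 nM, with an expected range of 28000 nM to 120000 nM.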

Compound 3, half-maximal effective concentration: 33300 nM
Beside the measured number, compound 3's estimate is 1.8-fold (0.26 log units) above it; low and high end bracket the measured number.
By their numbers in this assay, from the lowest: compounds 3, 1 and 2 (each within the scatter of the next).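

In this assay lengthening methoxy to propoxy gives a 1.6-fold lower number from compound 2 to compound 3 (0.21 log units; within the scatter) and so shows that this position tolerates a longer chain with no step beyond the scatter. Exchanging 2,6-dibromopyridin-4-yl for 2-chloro-6-propoxypyridin-4-yl gives a 1.4-fold lower number from compound 1 to compound 3 (0.13 log units; within the scatter) and so leaves all three compounds level with one another. No measurement at hand says why these numbers stay so close.

On these data alone, whether a longer chain such as hexyloxy, or an amine or carboxylic acid at the end of the propoxy chain, would move the number beyond the scatter remains open.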